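Hydroxy for imidazolyl on the anilino ring

This account rests on a few compounds, and the source may have more. Where it says the series, first, only, none or still open, it means among the compounds named here.

Of the compounds shown here, three sharing one core have been measured in a functional assay for inhibition, with Homo sapiens as the target; a lower number here means a stronger inhibitor, a higher number a weaker inhibitor. Compound 1 `c1cncc(-c2ccnc(Nc3ccc(-n4ccnc4)cc3)n2)c1` gives 1300 nM, compound 2 `c1ccc(-c2ccnc(Nc3ccc(-n4ccnc4)cc3)n2)nc1` gives 1400 nM, and compound 3 `c1coc(-c2ccnc(Nc3ccc(-n4ccnc4)cc3)n2)c1` gives 2200 nM. Compound 1 holds the lowest of the three numbers, although every step among them stays within the scatter: a 1.1-fold higher number from compound 1 to compound 2 (0.03 log units; within the scatter), a 1.7-fold higher number from compound 1 to compound 3 (0.23 log units; within the scatter) and a 1.6-fold higher number from compound 2 to compound 3 (0.20 log units; within the scatter). All three steps exchange one aromatic group on the pyrimidine carbon, and none of them touches the other end of the molecule.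

Compound 4 `Oc1ccc(Nc2nccc(-c3cccnc3)n2)cc1` departs from compound 1 in that other end: hydroxy in place of 1H-imidazol-1-yl on an aromatic carbon. The 1H-imidazol-1-yl leaves the six-membered aromatic ring of carbon only, para to a large group, and a hydroxy enters at that aromatic carbon. For the measured compounds named here, no measured pair in this set varies that position, so the existing steps say nothing about its size or direction. In the absence of any comparison, compound 4 is expected to stay close to compound 1, and the step of a 1.2-fold higher number from compound 1 to compound 4 (0.06 log units; within the scatter) is estimated to lie within the scatter, with wide uncertainty in both directions. Compound 4 is therefore estimated to give 1500 nM, within a range from 400 nM to 6000 nM, in this assay.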

Compound 4, half-maximal inhibitory concentration: 5100 nM
Compound 4: the middle estimate sits 3.4-fold (0.53 log units) below what was measured, and the stated range covers the measured number.
By their numbers in this assay, from the lowest: compounds 1, 2 and 3 (each within the scatter of the next); then compound 4.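

In this assay, the position on the six-membered aromatic ring of carbon only, para to a large group, proves sensitive to what it carries: the step is a 3.9-fold higher number from compound 1 to compound 4 (0.59 log units; beyond the scatter) and puts hydroxy in place of 1H-imidazol-1-yl. For the compounds shown here, it is the first step in this set to lie beyond the scatter, whereas the three exchanges of the aromatic group at the other end of the molecule all stayed within it, so this end of the molecule is the one that has so far moved the number. The lower number goes with the 1H-imidazol-1-yl and its five-membered aromatic ring rather than with the single-atom hydroxy, but no measurement at hand accounts for the difference.

The compounds shown leave open whether the higher number follows from losing the ring or from introducing the hydroxy, a question that a methoxy, an amine or a pyrazol-1-yl at this position would help to separate. They also leave open whether the same exchange has a similar effect with pyridin-2-yl or furan-2-yl at the other end, as in compound 2 and compound 3.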